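Ether swap on the core: isopropoxy for (oxolan-3-yl)oxy

The source may hold more compounds than are shown below. What is called first, only, known or untested is meant among the compounds shown, and "the series" means these compounds.

Measured in an assay on Sf9 cells for inhibition of histone-lysine N-methyltransferase EZH2 variant Y641N (Homo sapiens), read by scintillation counting, with a stated time of 60 min, in the presence of a further agent that is not named here; on this read-out higher numbers stand for weaker inhibition and lower numbers for stronger inhibition:
compound 1 `Cc1cc(C)c(CN2CCc3ccc(O[C@@H]4CCOC4)c(Cl)c3C2=O)c(=O)[nH]1`: 110 nM
compound 2 `Cc1cc(C)c(CN2CCc3c(F)cc(O[C@@H]4CCOC4)c(Cl)c3C2=O)c(=O)[nH]1`: 260 nM
compound 3 `Cc1cc(C)c(CN2CCc3c(Cl)cc(-c4c(C)n[nH]c4C)c(Cl)c3C2=O)c(=O)[nH]1`: 82 nM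

Within the data shown here, compound 1 lies within the scatter of compound 3 and gives a lower number than compound 2; the only single-point step known, a 2.4-fold higher number from compound 1 to compound 2 (0.37 log units; beyond the scatter), concerns a fluoro on the core and not the ether. Compound 4 `Cc1cc(C)c(CN2CCc3ccc(OC(C)C)c(Cl)c3C2=O)c(=O)[nH]1` carries isopropyl in place of oxolan-3-yl on an oxygen on an aromatic ring. Among the measured compounds shown here, no measured pair alters this ether, so the measured steps offer no direct guide; compound 3 exchanges the whole ether for a different group and cannot be read as a step of this kind. The expectation is therefore a change in this assay no larger than the scatter, a 1.2-fold higher number from compound 1 to compound 4 (0.07 log units; within the scatter). Compound 4 is estimated at 130 nM, with a range of 50 nM to 350 nM.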

Compound 4, half-maximal inhibitory concentration: 160 nM
The estimate for compound 4 lay 1.2-fold (0.09 log units) below the measured number; measured number inside the range.
By their numbers in this assay, from the lowest: compounds 3, 1, 4 and 2 (each within the scatter of the next, the first and the last beyond it).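

In this assay, isopropyl in place of oxolan-3-yl on an oxygen on an aromatic ring gives a 1.5-fold higher number from compound 1 to compound 4 (0.16 log units; within the scatter), which is within the scatter. This first single-point reading at this oxygen shows that the five-membered non-aromatic ring, its hydrogen-bond acceptor and its defined stereocentre can all be lost without a step beyond the scatter. No measured evidence bears on the reason for this result.

As far as these compounds go, whether an amine, a carboxylic acid or a longer chain on this oxygen would fit the same picture stays open. Also open, from the compounds shown here alone, is whether the fluoro step holds with isopropyl on this oxygen.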